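Chloro to methyl on the phenoxy ring: a small step

The source may report more compounds than this note shows. Statements on the series, on what has been measured and on what is new or still open speak of the compounds shown alone.

Of the compounds shown here, two have been measured in a functional assay on the whole organism (strain Wistar) for inhibition, with Rattus norvegicus as the target, read by paw edema, with stated times of 1 h and 3 h, at a dose of 10 mg/kg by the oral route; a higher number here means more inhibition at the dose given (going by the name of the read-out), a lower number less inhibition. Compound 1 `CC1=NN(C(=O)c2sc3ccccc3c2Cl)C(=O)/C1=N/Nc1ccccc1` gives 48.6% in this assay. Compound 2 `Clc1ccccc1OCc1nnc(-c2sc3ccccc3c2Cl)o1` gives 38.2% in this assay. Compound 2 thus stands lowest of the two numbers, and its nearest measured neighbour, compound 1, sits higher by a gap beyond the usual scatter. Among the measured compounds shown here, the two differ in more than one place, so no single structural step between them can be read from these values.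

Compound 3 `Cc1ccccc1OCc1nnc(-c2sc3ccccc3c2Cl)o1` has not yet been measured. It differs from compound 2 in one place: methyl in place of chloro on an aromatic carbon. Chloro leaves and methyl enters, each counting one heavy atom, on an aromatic carbon of a six-membered aromatic ring of carbon only, with no change in donors, acceptors, rings or charge. For the measured compounds named here, no measured pair shows an exchange of this kind, so there is no step to lean on. The expected step from compound 2 to compound 3 is a number 0.2 percentage points lower from compound 2 to compound 3 (within the scatter), that is, none beyond the scatter. Compound 3 is estimated at 38% in this assay, within a range from 24% to 52%.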

Compound 3, a percentage reported as inhibition, in the whole organism at one dose (the size of the read-out at that dose, not a potency): 33.7%
Compound 3: the middle estimate sits 4.3 percentage points above what was measured; the range from low to high includes it.
By their numbers in this assay, from the lowest: compounds 3 and 2 (each within the scatter of the next); then compound 1.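

In this assay, among the compounds shown here, methyl in place of chloro on an aromatic carbon, ortho to a large group, gives a number 4.5 percentage points lower from compound 2 to compound 3 (within the scatter), and this is the first single-place step the series offers. At this position, then, 2-chlorophenoxy and 2-methylphenoxy cannot be told apart at the dose given, so this one exchange of one heavy atom for another leaves the reading of paw edema inhibition within what repeated measurements would show, whichever of the two groups is present. Nothing measured here bears on why the two groups read alike, and the result rests on a single pair.

The compounds shown place only chloro and methyl on this aromatic carbon, so it remains open whether an amine, a carboxylic acid or a longer chain such as propyl at the same place would shift the number beyond the scatter. Also open, on these data alone, is how the same exchange reads elsewhere on the six-membered ring, while steps from compound 1 to the other two compounds cannot be read, since they differ from it in more than one place.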